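Swapping the amine on a sulfonyl in a bis-sulfonamide series

The source may report more compounds than this note shows. Statements on the series, on what has been measured and on what is new or still open speak of the compounds shown alone.

Compound 1 `CCOC(=O)[C@@H]1CCCN(S(=O)(=O)c2ccc(S(=O)(=O)N(C)Cc3ccccc3)cc2)C1` carries an ethyl ester on its core and a benzyl(methyl)amino group on one sulfonyl sulfur. In a functional assay on BXPC-3 cells (Homo sapiens) for inhibition, read by MTT assay, with a stated time of 7 days (on this read-out lower numbers stand for stronger inhibition and higher numbers for weaker inhibition), compound 1 gives > 30000 nM, which is a limit of the assay and not a number. Within this small set compound 1 stands at the limit of > 30000 nM in this assay, at which 1 of the 2 values shown sits, so its true potency is unknown beyond that limit. Compound 2 `CC(C)c1noc(N2CCN(C(=O)[C@@H]3CCCN(S(=O)(=O)c4ccc(S(=O)(=O)NC(C)(C)C)cc4)C3)CC2)n1` belongs to the same series and in this assay compound 2 gives 2600 nM. Compound 3 `CCCN(CC)S(=O)(=O)c1ccc(S(=O)(=O)N2CCC[C@@H](C(=O)OCC)C2)cc1` has not yet been tested; it differs from compound 1 by ethyl(propyl)amino in place of benzyl(methyl)amino on a sulfonyl sulfur. Within the data shown here, no measured pair shows this change, so no step size can be drawn from the data. Compound 3 is expected to give 40000 nM, within a range from 12000 nM to 150000 nM. That expectation means a step that the limit leaves unreadable from compound 1 to compound 3, a step not beyond the usual scatter.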

Compound 3, half-maximal inhibitory concentration: 300 nM
Estimate against measurement, compound 3: 130-fold (2.12 log units) above; the whole stated range lies above it.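

The choice of amine on this sulfonyl sulfur matters greatly with the rest of the molecule held constant: ethyl(propyl)amino in place of benzyl(methyl)amino gives an at least 100-fold lower number from compound 1 to compound 3 (2.00 log units; beyond the scatter). In this assay compound 1 gives > 30000 nM, which is a limit of the assay and not a number. The step therefore marks a minimum and not an exact size: the limit of > 30000 nM in this assay, at which 1 of the 3 values shown sits.

This single change both removes the aromatic ring and replaces a methyl and a benzyl with two open chains, so the compounds shown cannot separate these two differences, and compound 2 differs from both compounds in more than one place. A plain diethylamino group or a ring amine such as piperidine on the same sulfur would be needed to tell whether the ring's absence or the chains themselves go with the stronger value.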